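A few compounds are considered here, and "the series" means these few. Any claim that something is new, unique, unknown or untested is made for them only; others in the source may bear on it.

Of the compounds shown here, two built on one shared core have been measured in an ADME assay on MT4 cells (Homo sapiens) for cytotoxicity, read by MTT assay, with a stated time of 5 days; a higher number here means that more compound is tolerated, a lower number that less compound is tolerated. Compound 1 `COc1cc(Cc2cnc(/N=C3\C(=O)N(CN4CCCCC4C)c4ccc(Cl)cc43)nc2N)cc(OC)c1OC` gives 97.3 ug/mL in this assay. Compound 2 `COc1cc(Cc2cnc(/N=C3\C(=O)N(CN4CCN(c5cccc(Cl)c5)CC4)c4ccc(Cl)cc43)nc2N)cc(OC)c1OC` gives 39.2 ug/mL in this assay, the lower of the two numbers, and the gap to compound 1 lies beyond the usual scatter, so the cells tolerate less of compound 2. Compound 3 `COc1cc(Cc2cnc(/N=C3\C(=O)N(CN4CCN(c5ccccn5)CC4)c4ccc(Cl)cc43)nc2N)cc(OC)c1OC` has not yet been measured. It differs from compound 2 in one place: pyridin-2-yl in place of 3-chlorophenyl on an amine nitrogen in a ring. Within the data shown here, no pair of measured compounds differs at this same position, so there is nothing that shows how large such a swap is. The group that leaves and the group that enters are both one six-membered aromatic ring, and the step of a 1.3-fold higher number from compound 2 to compound 3 (0.11 log units; within the scatter) is therefore expected to be small, probably within the scatter, leaning slightly toward more tolerance. Compound 3 is estimated at 50 ug/mL, with a range from 20 ug/mL to 120 ug/mL.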

Compound 3, half-maximal cytotoxic concentration: 39.2 ug/mL
Compound 3: middle estimate off by 1.3-fold (0.11 log units), on the high side, within the range that was stated.
By their numbers in this assay, from the lowest: compounds 2 and 3 (each within the scatter of the next); then compound 1.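

In this assay, among these compounds, the swap on the amine nitrogen gives no change at the digits printed from compound 2 to compound 3 (within the scatter), the first direct reading at this position: a chlorine-bearing carbon ring and a pyridine ring give the same number here. The larger change, 4-(pyridin-2-yl)piperazin-1-yl in place of 2-methylpiperidin-1-yl, gives a 2.5-fold lower number from compound 1 to compound 3 (0.39 log units; beyond the scatter), so the lower tolerance relative to compound 1 appears with either of these two aromatic rings on the nitrogen. Nothing measured on these compounds explains why the swap leaves the number in place.

The compounds shown cover only two six-membered aromatic rings at this position, so it remains open whether a group without an aromatic ring, such as a methyl or an acetyl, would read the same. Going by these compounds, it is also open whether an unsubstituted phenyl would match them.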